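The source may report more compounds than this note shows. Statements on the series, on what has been measured and on what is new or still open speak of the compounds shown alone.

Two members of this series were examined in a functional assay on PC-3 cells (Homo sapiens) for cytotoxicity, read by sulforhodamine B assay, with a stated time of 48 h; on this read-out higher numbers stand for weaker inhibition of growth and lower numbers for stronger inhibition of growth. Compound 1, `COc1ccc(-c2cs/c(=N\NC(=O)c3ccc(O)cc3)n2-c2ccc(OC)cc2OC)cc1`, carries a 2,4-dimethoxyphenyl group on the ring nitrogen of the shared core, and in this assay compound 1 gives 3390 nM. Compound 2, `O=C(N/N=c1\scc(-c2ccc(Cl)cc2)n1-c1ccc(Cl)cc1Cl)c1ccc(O)cc1`, carries a 2,4-dichlorophenyl group at the same position, and in this assay compound 2 gives 3390 nM. Compound 2 therefore stands level with compound 1 at the digits shown, with no difference beyond the scatter between them.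

Compound 3, `COc1ccc(-n2c(-c3ccc(Cl)cc3)cs/c2=N\NC(=O)c2ccc(O)cc2)c(OC)c1`, has not yet been measured. It differs from compound 2 by 2,4-dimethoxyphenyl in place of 2,4-dichlorophenyl on an aromatic nitrogen. Since compound 1 and compound 2 give the same reading, no step beyond the scatter is expected from this exchange. The step from compound 2 to compound 3 in this assay is expected to be a 1.0-fold higher number from compound 2 to compound 3 (0.00 log units; within the scatter). Compound 3 is estimated at 3400 nM, within a range from 1500 nM to 8000 nM.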

Compound 3, concentration for 50% growth inhibition: 18200 nM
Beside the measured number, compound 3's estimate is 5.4-fold (0.73 log units) below it; the whole stated range lies below it.
By their numbers in this assay, from the lowest: compounds 1 and 2 (each within the scatter of the next); then compound 3.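

With the 4-chlorophenyl group held in place, this aromatic nitrogen is sensitive to the exchange in this assay: 2,4-dimethoxyphenyl in place of 2,4-dichlorophenyl gives a 5.4-fold higher number from compound 2 to compound 3 (0.73 log units; beyond the scatter). With 2,4-dimethoxyphenyl held instead, chloro in place of methoxy on an aromatic carbon gives a 5.4-fold higher number from compound 1 to compound 3 (0.73 log units; beyond the scatter), so the level reading of compound 1 and compound 2, which differ in two places, gave no measure of either place alone. Nothing available here accounts for either step.

Going by these compounds, whether the step at the aromatic nitrogen keeps its size when methoxy rather than chloro stands on that aromatic carbon remains open. So does the response at this nitrogen to an unsubstituted phenyl group, a 4-aminophenyl group or a 4-carboxyphenyl group.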